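Changing one ring atom on two related cores

A few compounds are considered here, and "the series" means these few. Any claim that something is new, unique, unknown or untested is made for them only; others in the source may bear on it.

Compound 1 `COc1ccc(C2=NN(c3ccccc3)C(c3ccc(C)cc3)C2S(=O)(=O)CC2=NCCO2)cc1`: 59.1%
Compound 2 `COc1ccc(-c2nn(-c3ccccc3)c(-c3ccc(C)cc3)c2S(=O)(=O)CC2=NCCS2)cc1`: "not active" (no number reported)
Compound 3 `COc1ccc(C2=NN(c3ccccc3)C(c3ccc(C)cc3)C2S(=O)(=O)CC2=NCCS2)cc1`: 39.4%

In a functional assay, read by Griess assay, with a stated time of 150 min, tested at 50 ug/mL (on this read-out lower numbers stand for a weaker effect and higher numbers for a stronger effect at the one concentration tested), compound 3 gives 39.4% and compound 1 gives 59.1%. The two share one core and differ only in a group of 5 heavy atoms (3 carbon, 1 nitrogen, 1 oxygen; one five-membered non-aromatic ring with 2 hetero atoms) in place of a group of 5 heavy atoms (3 carbon, 1 nitrogen, 1 sulfur; one five-membered non-aromatic ring with 2 hetero atoms), on a saturated chain carbon bound to a sulfonyl sulfur. This change made a step of a number 19.7 percentage points higher from compound 3 to compound 1 (beyond the scatter).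

Compound 2 is built on a different core; the difference between the two cores is not broken down here. In this assay compound 2 was reported as "not active" (no number reported), with no number attached, so it offers no starting value to which a step could be added.

Compound 4 `COc1ccc(-c2nn(-c3ccccc3)c(-c3ccc(C)cc3)c2S(=O)(=O)CC2=NCCO2)cc1` carries the core of compound 2 and differs from it in a group of 5 heavy atoms (3 carbon, 1 nitrogen, 1 oxygen; one five-membered non-aromatic ring with 2 hetero atoms) in place of a group of 5 heavy atoms (3 carbon, 1 nitrogen, 1 sulfur; one five-membered non-aromatic ring with 2 hetero atoms), on a saturated chain carbon bound to a sulfonyl sulfur. Since the place is the same in both pairs, this is the same change that took compound 3 to compound 1, now made on the other core. Going by the values given here, the only guide is that single step, and a step seen once on one core need not repeat on another. Because compound 2 showed "not active" (no number reported), an addition of the size seen from compound 3 to compound 1 would still leave compound 4 at a low reading, and there is a fair chance that it too returns no number. Compound 4 is therefore expected to give about 15% in this assay, estimated to lie between 0% and 40%.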

Compound 4, a percentage reported as activity, at one concentration (the size of the read-out at that concentration, not a potency): 61.6%
The estimate for compound 4 lay 46.6 percentage points below the measured number; the measured number lies above the stated range.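

Going by these compounds alone, compound 2 has no reported number, so no step from compound 2 to compound 4 can be read, even though the two differ in one place. The compounds shown leave open how large the effect of exchanging the sulfur-containing ring for the oxygen-containing ring is on this core, and whether it matches the change seen on the other core. No supporting data bear on this result.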